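Benzyl for methyl on a para sulfone: a step in prostanoid receptor antagonism

The source may hold more compounds than are shown below. What is called first, only, known or untested is meant among the compounds shown, and "the series" means these compounds.

Measured compounds and values:
- compound 1, `Cc1c(Cc2cc(Br)ccc2S(=O)(=O)c2ccccc2)c2c(n1CC(=O)O)CCNC2=O`: 3.9 nM
- compound 2, `CNC(=O)c1cccc(S(=O)(=O)c2ccccc2Cc2c3c(n(CC(=O)O)c2C)CCNC3=O)c1`: 240 nM
- compound 3, `Cc1c(Cc2ccc(S(C)(=O)=O)cc2)c2c(n1CC(=O)O)CCNC2=O`: 900 nM

All three share one core and were tested in a functional assay on CHO.K1 cells for antagonist activity at prostaglandin D2 receptor 2 (Homo sapiens), read by GTPgammaS binding, with a stated time of 1 h; a higher number here means a weaker inhibitor, a lower number a stronger inhibitor. Among the three numbers, compound 3 gives the highest one, 900 nM, so it is the weakest inhibitor of this set, and the two others stand beyond the scatter from it: compound 2 at 240 nM and compound 1 at 3.9 nM. No two of the three differ in a single place, so none of their gaps can be read as a clean step.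

Compound 4, `Cc1c(Cc2ccc(S(=O)(=O)Cc3ccccc3)cc2)c2c(n1CC(=O)O)CCNC2=O`, has not yet been tested in this assay. It departs from compound 3 in one place: phenyl in place of hydrogen on a saturated chain carbon bound to a sulfonyl sulfur. The larger sulfone substituents on the two more potent compounds suggest that enlarging the methylsulfonyl of compound 3 is more likely to lower the number than to raise it, although neither compound 1 nor compound 2 carries its sulfone at the same place as compound 3. The step from compound 3 to compound 4 in this assay is therefore expected to be a 3.0-fold lower number from compound 3 to compound 4 (0.48 log units; beyond the scatter), toward a stronger inhibitor. Compound 4 is expected to give 300 nM, within a range of 70 nM to 1500 nM.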

Compound 4, half-maximal inhibitory concentration: 3 nM
Compound 4: the middle estimate sits 100-fold (2.00 log units) above what was measured; the measured number lies below the stated range.
By their numbers in this assay, from the lowest: compounds 4 and 1 (each within the scatter of the next); then compound 2; then compound 3.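

In this assay, going by these compounds alone, a 300-fold lower number from compound 3 to compound 4 (2.48 log units; beyond the scatter) is the first step in this set that can be read as a single change, and it shows that the methylsulfonyl of compound 3 is far from the limit of what this position accepts. Going from methylsulfonyl to benzylsulfonyl, with phenyl in place of hydrogen on a saturated chain carbon bound to a sulfonyl sulfur, is enough on its own to produce a large step; the earlier compounds could not show this, since no two of them differ in one place and neither compound 1 nor compound 2 carries its sulfone at the same place as compound 3. No measurement given here bears on why this change has such an effect.

The compounds shown leave open whether the step depends on the aromatic ring itself, which an ethyl, a cyclohexylmethyl or a longer chain such as phenethyl on the sulfonyl would help to separate. From the compounds shown here alone, it also remains open whether a fluorine, a methoxy or a carboxylic acid on the new phenyl ring would hold the number that compound 4 gives, 3 nM, or move it.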